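The source may hold more compounds than are shown below. What is called first, only, known or untested is meant among the compounds shown, and "the series" means these compounds.

Compound 1, `O=C(NO)c1ccc(NCc2nc(-c3ccc(Cl)cc3)nn2-c2ccccc2)cc1`, gives 67.2% in an assay on Sf9 cells for inhibition of protein deacetylase HDAC6 (Homo sapiens), read by fluorescence, with a stated time of 40 min, tested at 100 nM; a higher number here means more inhibition at the concentration tested (going by the name of the read-out), a lower number less inhibition.
Compound 2, `Cc1cccc(-c2nc(CNc3ccc(C(=O)NO)cc3)n(-c3ccccc3)n2)c1`, gives 64.1% in this assay.

Within the data shown here, of these two numbers, compound 2 stands lowest, with compound 1 as its only neighbour. Among the measured compounds shown here, the one measured step, a number 3.1 percentage points lower from compound 1 to compound 2 (within the scatter), is so small that the two compounds cannot be told apart on this read-out.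

Compound 3, `O=C(NO)c1ccc(NCc2nc(-c3ccncc3)nn2-c2ccccc2)cc1`, has not yet been measured. It differs from compound 2 in one place: pyridin-4-yl in place of 3-methylphenyl on an aromatic carbon.

For the measured compounds named here, only one measured step bears on this change, and it is the same kind of move: one six-membered aromatic ring exchanged for another on the same aromatic carbon of the shared core. That step was a number 3.1 percentage points lower from compound 1 to compound 2 (within the scatter), within the scatter. Going by the values given here, the new ring, however, carries a hydrogen-bond acceptor, and no measured compound tests a ring of that kind at this place, so the range is kept wide.

For compound 3 in this assay the estimate is 62%, expected to fall between 45% and 78%. This estimate means an expected step of a number 2.1 percentage points lower from compound 2 to compound 3 (within the scatter), not beyond the scatter.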

Compound 3, a percentage reported as inhibition, at one concentration (the size of the read-out at that concentration, not a potency): 30.8%
Compound 3: the middle estimate sits 31.2 percentage points above what was measured, and the stated range ends above it.
By their numbers in this assay, from the lowest: compound 3; then compounds 2 and 1 (each within the scatter of the next).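

This position on the shared core, the aromatic carbon of the five-membered ring, turns out to be sensitive to which six-membered ring it carries: in this assay, pyridin-4-yl in place of 3-methylphenyl gives a number 33.3 percentage points lower from compound 2 to compound 3 (beyond the scatter), and pyridin-4-yl in place of 4-chlorophenyl gives a number 36.4 percentage points lower from compound 1 to compound 3 (beyond the scatter). Among these compounds, the two rings of carbon only could not be told apart on this read-out, so the earlier step gave no sign that a swap at this place could matter so much; the pyridin-4-yl ring, with its ring nitrogen and its hydrogen-bond acceptor, is the first of the three to stand apart. Nothing available explains the drop.

The pyridin-4-yl ring also carries no chloro or methyl group, so the compounds shown cannot separate the effect of adding the ring nitrogen from that of having no such group, and a plain phenyl ring at this place would be the direct comparison. Also open, on these data alone, is whether a phenyl ring bearing an amine or a carboxylic acid would behave like compound 3 or like compound 1 and compound 2.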